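A few compounds are considered here, and "the series" means these few. Any claim that something is new, unique, unknown or untested is made for them only; others in the source may bear on it.

In a functional assay for inhibition of sodium- and chloride-dependent glycine transporter 1 (Rattus norvegicus), with a stated time of 30 min, in the presence of a further agent that is not named here (on this read-out lower numbers stand for stronger inhibition and higher numbers for weaker inhibition), compound 1 `Cc1ccc(/C(=C\CC(N)C(=O)O)c2ccc(F)cc2F)cc1` gives 9560 nM. For compound 2 `NC(C/C=C(\c1ccsc1)c1ccc(F)cc1F)C(=O)O` this assay reports only a limit, > 10000 nM. For compound 3 `NC(C/C=C(\c1cccnc1)c1ccc(F)cc1F)C(=O)O` this assay likewise reports only a limit, > 10000 nM, so compound 3 stands on the limit of > 10000 nM in this assay, at which 2 of the 3 values shown sit, rather than on a number. The step of an at least 1.0-fold higher number from compound 1 to compound 2 (0.01 log units; that floor lies within the scatter) and the step of an at least 1.0-fold higher number from compound 1 to compound 3 (0.01 log units; that floor lies within the scatter) each rest on that limit, and the step that the two limits leave unreadable from compound 2 to compound 3 cannot be read. Compound 4 `NC(C/C=C(\c1ccccc1)c1ccc(F)cc1F)C(=O)O` differs from compound 3 by phenyl in place of pyridin-3-yl on a double-bonded chain carbon bound to an aromatic carbon and a double-bonded chain carbon. Compound 4 is expected to give a high number because compound 1 with 4-methylphenyl at that place gives 9560 nM. The expected step is a step that the limit leaves unreadable from compound 3 to compound 4. Compound 4 is therefore estimated at 12000 nM, in the range 5000 nM to 30000 nM.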

Compound 4, half-maximal inhibitory concentration: 9500 nM
Estimate against measurement, compound 4: 1.3-fold (0.10 log units) above; the measured number falls inside the stated range.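

In this assay, phenyl at this place gives an at least 1.0-fold lower number from compound 3 to compound 4 (0.02 log units; that floor lies within the scatter) and an at least 1.0-fold lower number from compound 2 to compound 4 (0.02 log units; that floor lies within the scatter), so neither step can be shown to exceed the scatter, and both rest on limits: the limit of > 10000 nM in this assay, at which 2 of the 4 values shown sit. Phenyl and 4-methylphenyl cannot be told apart here, with a 1.0-fold lower number from compound 1 to compound 4 (0.00 log units; within the scatter). Together these results show that a plain phenyl at this place does not clearly separate from the other groups shown. Going by these compounds, it remains open whether an amine or a carboxylic acid on that phenyl would give a lower number, and what compound 2 and compound 3 would give beyond their limits.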